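The source may hold more compounds than are shown below. What is called first, only, known or untested is meant among the compounds shown, and "the series" means these compounds.

In an ADME assay on HEL cells (Homo sapiens) for cytotoxicity, with a stated time of 3 days (on this read-out lower numbers stand for higher toxicity in this test and higher numbers for lower toxicity in this test), compound 1 `CCC1(Cc2ccccc2)OS(=O)(=O)C=C1OCc1ccccc1` gives 200000 nM. Compound 2 `CCC1(Cc2ccccc2)OS(=O)(=O)C=C1OCCCCc1ccccc1` gives 99000 nM in this assay, and compound 3 `CCC1(Cc2ccccc2)OS(=O)(=O)C=C1OCc1cccc(Cl)c1` gives 50000 nM. Compound 3 thus carries the lowest of the three numbers: the step of a 4.0-fold lower number from compound 1 to compound 3 (0.60 log units; beyond the scatter) lies beyond the scatter, while the step of a 2.0-fold lower number from compound 2 to compound 3 (0.30 log units; within the scatter) stays within it. Compound 4 `CCC1(Cc2ccccc2)OS(=O)(=O)C=C1OCc1ccc(Br)cc1` differs from compound 3 by 4-bromophenyl in place of 3-chlorophenyl on a saturated chain carbon bound to an oxygen on an unsaturated carbon. For the measured compounds named here, the only measured step that brings a halogen onto that ring, a 4.0-fold lower number from compound 1 to compound 3 (0.60 log units; beyond the scatter), was modest, and no measured step exchanges one halogen for another, so compound 3 itself is the closest guide. Compound 4 is therefore expected to show a step of a 1.4-fold lower number from compound 3 to compound 4 (0.15 log units; within the scatter), within the scatter. The value of compound 4 in this assay is estimated at 35000 nM, between 12000 nM and 100000 nM.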

Compound 4, half-maximal cytotoxic concentration: 171000 nM
Compound 4: the middle estimate sits 4.9-fold (0.69 log units) below what was measured, outside the stated range (above it).
By their numbers in this assay, from the lowest: compounds 3, 2, 4 and 1 (each within the scatter of the next, the first and the last beyond it).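

At this place, on a saturated chain carbon bound to an oxygen on an unsaturated carbon, a halogen on the ring need not lower the number in this assay: bromo in place of hydrogen gives only a 1.2-fold lower number from compound 1 to compound 4 (0.07 log units; within the scatter), and compound 3 with its chloro goes against this. Which halogen-bearing ring sits there counts, with a 3.4-fold higher number from compound 3 to compound 4 (0.53 log units; beyond the scatter), whereas 4-bromophenyl in place of 3-phenylpropyl gives a 1.7-fold higher number from compound 2 to compound 4 (0.24 log units; within the scatter). No measurement shown accounts for these differences.

Going by these compounds, whether the halogen itself or its place on the ring carries the step stays open. On these data alone, how a 4-chlorophenyl or a 3-bromophenyl group would read here also remains open.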